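This account rests on a few compounds, and the source may have more. Where it says the series, first, only, none or still open, it means among the compounds named here.

In a functional assay on PLC-PRF-5 cells (Homo sapiens) for inhibition, read by MTT assay, with a stated time of 72 h (a higher number here means a weaker inhibitor, a lower number a stronger inhibitor), compound 2 `Nc1nc2cc(-c3nn(CCCCCCCCCC(=O)NO)c4ncnc(N)c34)ccc2o1` gives > 100000 nM, which is a limit of the assay and not a number. Compound 1 `Nc1ncnc2c1c(-c1cnc3[nH]ccc3c1)nn2CCCCCC(=O)NO` gives > 150000 nM, also a limit. Among the measured compounds shown here, compound 3 `Nc1ncnc2c1c(-c1cnc3[nH]ccc3c1)nn2CCCCCCCCCC(=O)NO` gives 34200 nM, the only true number so far. Compound 4 `Nc1nc2cc(-c3nn(CCCCCC(=O)NO)c4ncnc(N)c34)ccc2o1` carries hydroxycarbamoyl in place of 4-(hydroxycarbamoyl)butyl on a saturated chain carbon, five bonds along the chain from an aromatic nitrogen. The same difference has been measured once, on another core, as an at least 4.3-fold lower number from compound 1 to compound 3 (0.64 log units; beyond the scatter), where the longer chain gave the lower number. The step between the two cores, an at least 2.9-fold lower number from compound 2 to compound 3 (0.46 log units; beyond the scatter), shows the core of compound 2 on the higher side. A move towards a higher number is therefore expected, read as a step that the limit leaves unreadable from compound 2 to compound 4. Compound 4 is estimated at 200000 nM, within 100000 nM to 500000 nM, and may well be reported only as a limit.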

Compound 4, half-maximal inhibitory concentration: > 50000 nM
Compound 4: a limit, no number; the forecaster's own chance of this, stated with the estimate: 85%; the middle value does not contradict the limit.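

Compound 2 and compound 4 both stand only as limits in this assay, not as numbers, so the step between them cannot be read. The compounds shown leave open whether the shorter chain of compound 4 changes the number on this core at all, and in which direction.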